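A few compounds are considered here, and "the series" means these few. Any claim that something is new, unique, unknown or untested is made for them only; others in the source may bear on it.

Of the compounds shown here, three that share a core have been measured in a functional assay on aorta (Rattus norvegicus, strain Wistar) for inhibition, with a stated time of 60 min; a lower number here means that less compound is needed, a higher number that more compound is needed for the effect. Compound 1 `FC(F)(F)c1ccc2[nH]c(-c3ccccc3)nc2c1` gives 369000 nM in this assay. Within the data shown here, compound 3 `CN(C)c1ccc(-c2nc3cc(C(F)(F)F)ccc3[nH]2)cc1` gives 550000 nM, and the only single-point step measured so far is a 1.5-fold higher number from compound 1 to compound 3 (0.17 log units; within the scatter). Compound 2 `COc1cc(-c2nc3cc([N+](=O)[O-])ccc3[nH]2)ccc1O` gives 1810 nM, the lowest of the three numbers, with compound 1 nearest and compound 3 furthest, both beyond the scatter.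

Compound 4 `COc1cc(-c2nc3cc(C(F)(F)F)ccc3[nH]2)ccc1O` has not yet been measured. It differs from compound 2 in one place: trifluoromethyl in place of nitro on an aromatic carbon. Among the measured compounds shown here, no measured step exchanges a nitro for a trifluoromethyl, so nothing here bears directly on this change; the one measured step, a 1.5-fold higher number from compound 1 to compound 3 (0.17 log units; within the scatter), touches a different part of the structure. The two trifluoromethyl compounds, compound 1 with 369000 nM and compound 3 with 550000 nM, give far higher numbers than compound 2, yet they also differ from compound 2 elsewhere, so this is only loose guidance. Compound 4 is therefore expected to need more compound than compound 2, with an estimated step of a 6.6-fold higher number from compound 2 to compound 4 (0.82 log units; beyond the scatter). The estimate for compound 4 is 12000 nM, expected to fall between 2500 nM and 80000 nM.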

Compound 4, half-maximal effective concentration: 34800 nM
Estimate against measurement, compound 4: 2.9-fold (0.46 log units) below; the measured number falls inside the stated range.
By their numbers in this assay, from the lowest: compound 2; then compound 4; then compounds 1 and 3 (each within the scatter of the next).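

Exchanging nitro for trifluoromethyl on this aromatic carbon, with the rest of the molecule unchanged, gives a 19-fold higher number from compound 2 to compound 4 (1.28 log units; beyond the scatter) in this assay. Among these compounds, the only earlier step involved a different part of the structure and stayed within the scatter, so this is the first direct sign that the compound's number is sensitive to the group at this position. Nothing available explains why the step is so large.

Among the compounds shown here, because only two groups have been compared at this position, it remains open whether a nitrile, an amine or a carboxylic acid there would give a number closer to that of compound 2 or compound 4. It is also unknown whether the same exchange would produce a step of similar size with a different group elsewhere on the molecule.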